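Anilino in Place of 4-Methylpiperidin-1-yl: Compound 4 Expected

A few compounds are considered here, and "the series" means these few. Any claim that something is new, unique, unknown or untested is made for them only; others in the source may bear on it.

Compound 1 `CC1CCN(c2nc(Cl)nc3c2ncn3Cc2ccc(/C=C/C(=O)Nc3ccccc3N)cc2)CC1` gives 10.8% in a functional assay on NCI-H460 cells (Homo sapiens) for antiproliferative activity, read by CCK-8 assay, with a stated time of 72 h, tested at 8 uM (on this read-out higher numbers stand for a stronger effect at the one concentration tested and lower numbers for a weaker effect), the lowest of the three numbers measured here. Compound 2 `CCCCn1cnc2c(Nc3ccccc3)nc(NCOCc3ccc(/C=C/C(=O)Nc4ccccc4N)cc3)nc21` gives 34.2%, and compound 3 `CC1CCN(c2nc(Cl)nc3c2ncn3Cc2ccc(C(=O)Nc3ccccc3N)cc2)CC1` gives 40.9%. Among the measured compounds shown here, the only single-place step measured, a number 30.1 percentage points higher from compound 1 to compound 3 (beyond the scatter), concerns the linker to the aminophenyl amide rather than the group changed here. Compound 4 `Nc1ccccc1NC(=O)/C=C/c1ccc(Cn2cnc3c(Nc4ccccc4)nc(Cl)nc32)cc1` differs from compound 1 by anilino in place of 4-methylpiperidin-1-yl on an aromatic carbon. For the measured compounds named here, no measured step bears directly on this change; compound 2, which also carries an anilino group but differs from compound 1 in several further places, shows the higher number. Compound 4 is therefore expected to give 22%, within 6% to 42%. The expected step of a number 11.2 percentage points higher from compound 1 to compound 4 (beyond the scatter) is a modest rise carrying wide uncertainty.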

Compound 4, a percentage reported as inhibition, at one concentration (the size of the read-out at that concentration, not a potency): 28.7%
Compound 4: the middle estimate sits 6.7 percentage points below what was measured, within the range that was stated.
By their numbers in this assay, from the lowest: compound 1; then compounds 4, 2 and 3 (each within the scatter of the next, the first and the last beyond it).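

In this assay the change at the aromatic carbon next to the ring nitrogen brings a number 17.9 percentage points higher from compound 1 to compound 4 (beyond the scatter) and shows that this position responds to the group it carries. The two groups match in heavy atoms, but anilino brings an aromatic ring of carbon only and a hydrogen-bond donor. No evidence bears on why the number rises. Still open, from the compounds shown here alone, is how a morpholin-4-yl group would read at this position. Also open, going by these compounds, is whether anilino would bring a similar step with the (2-aminophenyl)carbamoyl group of compound 3.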